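Ortho-fluoro addition on the distal phenyl ring of compound 3

The source may report more compounds than this note shows. Statements on the series, on what has been measured and on what is new or still open speak of the compounds shown alone.

Compound 3 `COc1cc2c(Oc3ccc(NC(=O)c4nccc(-c5ccc(F)cc5)n4)cc3F)ccnc2cc1OCCCN1CCN(C)CC1` gives the lowest number among the three measured compounds in a functional assay on NCI-H460 cells (Homo sapiens) for cytotoxicity, read by MTT assay, with a stated time of 72 h; on this read-out lower numbers stand for stronger inhibition and higher numbers for weaker inhibition: compound 3 gives 63 nM. Its nearest neighbour is compound 2 `COc1cc2c(Oc3ccc(NC(=O)c4nccc(-c5ccc(C)cc5)n4)cc3F)ccnc2cc1OCCCN1CCN(C)CC1`, which in this assay gives 160 nM; the furthest is compound 1 `COc1cc2c(Oc3ccc(NC(=O)c4nccc(-c5ccc(F)cc5F)n4)cc3F)ccnc2cc1OCCCN1CCCCC1`, which gives 550 nM. Among the measured compounds shown here, the only single-point step measured so far is a 2.5-fold lower number from compound 2 to compound 3 (0.40 log units; beyond the scatter).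

Compound 4 `COc1cc2c(Oc3ccc(NC(=O)c4nccc(-c5ccc(F)cc5F)n4)cc3F)ccnc2cc1OCCCN1CCN(C)CC1` differs from compound 3 by fluoro in place of hydrogen on an aromatic carbon. For the measured compounds named here, no measured step tests this exact change. The step of a 2.5-fold lower number from compound 2 to compound 3 (0.40 log units; beyond the scatter) concerns the same phenyl ring but a different position and a different exchange, so it bears only loosely. Compound 1 carries the same 2,4-difluorophenyl as compound 4, yet it also differs from compound 3 in the amine of the side chain; in this assay compound 1 gives 550 nM, whereas compound 3 gives 63 nM, and this gap cannot be split between the two changes.

On this basis compound 4 is expected to give a somewhat higher number than compound 3, the step of a 2.4-fold higher number from compound 3 to compound 4 (0.38 log units; beyond the scatter) being a modest one and possibly within the scatter. The estimate for compound 4 is 150 nM, within a range of 50 nM to 450 nM.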

Compound 4, half-maximal inhibitory concentration: 450 nM
Compound 4: middle estimate off by 3.0-fold (0.48 log units), on the low side, within the range that was stated.
By their numbers in this assay, from the lowest: compound 3; then compound 2; then compounds 4 and 1 (each within the scatter of the next).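

Working notes on the fluoro addition: in this assay, adding fluoro to the 4-fluorophenyl ring, at the place ortho to a large group, is far from neutral (in a 7.1-fold higher number from compound 3 to compound 4 (0.85 log units; beyond the scatter)), and this is the largest single-place step in the series so far. Among the compounds carrying the 4-methylpiperazin-1-yl side chain, 2,4-difluorophenyl also falls behind 4-methylphenyl (in a 2.8-fold higher number from compound 2 to compound 4 (0.45 log units; beyond the scatter)), so the 4-fluorophenyl ring of compound 3 remains the best of the three rings tested with this side chain. The side-chain exchange of piperidin-1-yl for 4-methylpiperazin-1-yl does not register on the 2,4-difluorophenyl ring (in a 1.2-fold lower number from compound 1 to compound 4 (0.09 log units; within the scatter)), which ties the high number of compound 1 to its ring rather than to its amine, at least on this ring.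

Nothing available accounts for the loss on adding this fluoro. Still open, on these data alone, are whether chloro or methoxy at the same place carries a similar loss, and whether the side-chain exchange, or a morpholin-4-yl side chain, stays equally silent on the 4-fluorophenyl ring.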